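Swapping Chloro for Methoxy in a Cell Growth Assay

This account rests on a few compounds, and the source may have more. Where it says the series, first, only, none or still open, it means among the compounds named here.

Of the compounds shown here, three have been measured in a functional assay on HT-29 cells (Homo sapiens) for antiproliferative activity, with a stated time of 72 h; on this read-out lower numbers stand for stronger inhibition and higher numbers for weaker inhibition. Compound 1 `COc1ccc(C2=NN(c3nc(-c4ccccc4)c(C#N)c(=O)n3C)C(c3ccc(OC)cc3)C2)cc1` gives 9420 nM in this assay, compound 2 `COc1ccc(C2CC(c3ccccc3)=NN2c2nc(-c3ccc(Cl)cc3)c(C#N)c(=O)n2C)cc1` gives 11000 nM, and compound 3 `COc1ccc(C2CC(c3ccc(Cl)cc3)=NN2c2nc(-c3ccc(Cl)cc3)c(C#N)c(=O)n2C)cc1` gives 15100 nM. Compound 3 carries the highest of the three numbers, yet it lies within the scatter of both others, so no ordering among the three can be claimed. Going by the values given here, the only single-point step measured, a 1.4-fold higher number from compound 2 to compound 3 (0.14 log units; within the scatter), stayed within the scatter.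

Compound 4 `COc1ccc(C2=NN(c3nc(-c4ccc(Cl)cc4)c(C#N)c(=O)n3C)C(c3ccc(OC)cc3)C2)cc1` differs from compound 3 in one place: methoxy in place of chloro on an aromatic carbon. Among the compounds with values here, no measured step covers this exact exchange. Compounds 2 and 4 differ by hydrogen against methoxy at the same carbon, and compounds 1 and 4 differ elsewhere in the molecule, so neither pair supplies a direct comparison. Within the data shown here, with the one measured step at this carbon being small, the expectation for compound 4 is a change no larger than the scatter, a 1.4-fold lower number from compound 3 to compound 4 (0.14 log units; within the scatter). Compound 4 is therefore estimated at 11000 nM, with a range from 5000 nM to 25000 nM.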

Compound 4, half-maximal inhibitory concentration: 18200 nM
Estimate against measurement, compound 4: 1.7-fold (0.22 log units) below; low and high end bracket the measured number.
By their numbers in this assay, from the lowest: compounds 1, 2, 3 and 4 (each within the scatter of the next).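

In this assay, this aromatic carbon can now be read with three groups, hydrogen, chloro and methoxy, and both steps to methoxy stay within the scatter: a 1.2-fold higher number from compound 3 to compound 4 (0.08 log units; within the scatter) and a 1.7-fold higher number from compound 2 to compound 4 (0.22 log units; within the scatter). Compound 4 also gives a second reading of chloro in place of hydrogen, a 1.9-fold higher number from compound 1 to compound 4 (0.29 log units; within the scatter), so this exchange can now be compared across two cores. The two readings agree: the same change on two cores in this assay, a 1.4-fold higher number (0.14 log units; within the scatter) from compound 2 to compound 3 and a 1.9-fold higher number (0.29 log units; within the scatter) from compound 1 to compound 4, 1.4-fold (0.15 log units) apart, within the scatter of two such steps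

Going by these compounds, whether any group at this carbon can move the number beyond the scatter remains open, since only hydrogen, chloro and methoxy appear there. An amine, a carboxylic acid or a longer chain such as butoxy at this carbon would test this, and the four compounds give no indication of what those groups would do.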